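From Dodecyl to tert-Butyl on Compound 2

A few compounds are considered here, and "the series" means these few. Any claim that something is new, unique, unknown or untested is made for them only; others in the source may bear on it.

In a functional assay on HeLa cells (Homo sapiens) for antiproliferative activity, read by MTT assay, with a stated time of 48 h (on this read-out lower numbers stand for stronger inhibition and higher numbers for weaker inhibition), compound 2 `CCCCCCCCCCCCNc1nc2ccccc2nc1Oc1ccc(C(=O)N[C@@H](C)C(=O)OC)cc1` gives 28500 nM and stands level, within the scatter, with compound 1 `COC(=O)[C@H](C)NC(=O)c1ccc(Oc2nc3ccccc3nc2C)cc1` at 32200 nM and compound 3 `CCCCCCCCCCCCNc1nc2ccccc2nc1Oc1ccc(C(=O)N[C@H](C(=O)OC)[C@H](C)CC)cc1` at 40300 nM on the same read-out. Compound 4 `COC(=O)[C@H](C)NC(=O)c1ccc(Oc2nc3ccccc3nc2NC(C)(C)C)cc1` differs from compound 2 by one change, tert-butyl in place of dodecyl on a nitrogen on an aromatic ring in full: tert-butyl in place of dodecyl on a nitrogen on an aromatic ring. For the measured compounds named here, the one measured step of a 1.4-fold higher number from compound 2 to compound 3 (0.15 log units; within the scatter) lies elsewhere on the molecule and stays within the scatter. Compound 1 carries no dodecyl and still gives 32200 nM so no step beyond the scatter is expected in this assay for this change. The expected step is a 1.1-fold higher number from compound 2 to compound 4 (0.02 log units; within the scatter) on this evidence. Compound 4 is estimated at 30000 nM with an expected range from 13000 nM to 70000 nM in this test.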

Compound 4, half-maximal inhibitory concentration: 55200 nM
Compound 4: middle estimate off by 1.8-fold (0.26 log units), on the low side, within the range that was stated.
By their numbers in this assay, from the lowest: compounds 2, 1, 3 and 4 (each within the scatter of the next).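

In this assay, tert-butyl in place of dodecyl on the nitrogen gives a 1.9-fold higher number from compound 2 to compound 4 (0.29 log units; within the scatter), so tert-butyl and dodecyl are not told apart here. (Tert-butyl)amino in place of methyl on the aromatic carbon gives a 1.7-fold higher number from compound 1 to compound 4 (0.23 log units; within the scatter), which also stays within the scatter. Across these three groups, this position has not yet produced a step beyond the scatter.

From the compounds shown here alone, whether an unsubstituted amine or a morpholine at this place would read differently stays open. Nothing available explains these numbers.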